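The source may report more compounds than this note shows. Statements on the series, on what has been measured and on what is new or still open speak of the compounds shown alone.

Measured compounds:
compound 1, `C=C1CC[C@@H]2[C@](C)(COC(=O)c3cccnc3)[C@H](OC(=O)c3cccnc3)CC[C@@]2(C)[C@@H]1/C=C/C1=CCOC1=O`: "not active" (no number reported)
compound 2, `C=C1CC[C@@H]2[C@](C)(CO)[C@H](O)CC[C@@]2(C)[C@@H]1/C=C/C1=C/C(=C/c2ccc(Cl)cc2)OC1=O`: 58.5%

Of the compounds shown here, two have been tested in a functional assay on PC-3 cells (Homo sapiens), read by wound healing assay, with a stated time of 48 h, tested at 10 uM; on this read-out lower numbers stand for less inhibition and higher numbers for more inhibition at the one concentration tested (going by the name of the read-out). Compound 1, `C=C1CC[C@@H]2[C@](C)(COC(=O)c3cccnc3)[C@H](OC(=O)c3cccnc3)CC[C@@]2(C)[C@@H]1/C=C/C1=CCOC1=O`, is reported in this assay as "not active" (no number reported), with no number attached to that entry. Going by the values given here, compound 2, `C=C1CC[C@@H]2[C@](C)(CO)[C@H](O)CC[C@@]2(C)[C@@H]1/C=C/C1=C/C(=C/c2ccc(Cl)cc2)OC1=O`, gives 58.5% in this assay and is therefore the only compound with a numerical result; with nothing but the unnumbered entry for compound 1 beside it, no ranking can be drawn from these two. The unmeasured compound 3, `C=C1CC[C@@H]2[C@](C)(CO)[C@H](O)CC[C@@]2(C)[C@@H]1/C=C/C1=C/C(=C/c2ccc(F)cc2)OC1=O`, differs from compound 2 in a single spot: fluoro in place of chloro on an aromatic carbon. Among the compounds with values here, no step between two measured compounds is available, so the size of this exchange cannot be read from the data themselves. The step is expected to be a number 6.5 percentage points lower from compound 2 to compound 3 (within the scatter), a shift that would not reach beyond the usual scatter of the read-out. Compound 3 is accordingly estimated at 52% in this assay, within a range from 32% to 68%.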

Compound 3, a percentage reported as inhibition, at one concentration (the size of the read-out at that concentration, not a potency): 34.3%
Estimate against measurement, compound 3: 17.7 percentage points above; the range from low to high includes it.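

In this assay, going by these compounds alone, the exchange of chloro for fluoro on the aromatic carbon gives the first step that can be read directly: a number 24.2 percentage points lower from compound 2 to compound 3 (beyond the scatter). Compound 1 carried no number, and compound 2 stood alone, so the earlier entries could not show whether this spot responds to a change at all; this pair shows that it does, since a change of one halogen atom, with the rest of the structure the same, moves the read-out beyond the usual scatter, and compound 3 still gives 34.3%, a measurable result. No measurement shown here speaks to what lies behind this difference.

The compounds shown leave open how bromo, methoxy, an amine or a plain unsubstituted phenyl would behave on this same ring, so one pair fixes neither a trend across groups nor a best choice at this spot. They also leave open whether the step from 4-chlorophenyl to 4-fluorophenyl would be the same size on another version of the shared core, such as one carrying the esters of compound 1.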